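Swapping the aryl sulfonyl halogen pattern in a benzofuran series

This account rests on a few compounds, and the source may have more. Where it says the series, first, only, none or still open, it means among the compounds named here.

Measured so far:
compound 1, `CCN(CC)c1ccc2cc(C(=O)c3ccc(N4CCN(S(=O)(=O)c5ccc([N+](=O)[O-])cc5)CC4)cc3)oc2c1`, 24400 nM
compound 2, `CCN(CC)c1ccc2cc(C(=O)c3ccc(N4CCN(S(=O)(=O)c5ccc(C(F)(F)F)cc5)CC4)cc3)oc2c1`, 11100 nM
compound 3, `CCN(CC)c1ccc2cc(C(=O)c3ccc(N4CCN(S(=O)(=O)c5ccc(F)cc5)CC4)cc3)oc2c1`, 16400 nM

All three share one core and differ only in the group carried on the aromatic ring attached to the sulfonyl sulfur. In a functional assay on A549 cells (Homo sapiens) for cytotoxicity, read by MTT assay, with a stated time of 48 h (a lower number here means a stronger inhibitor, a higher number a weaker inhibitor), compound 3 gives 16400 nM, which places it second highest of the three numbers; its nearest neighbour is compound 2 and the furthest is compound 1, and both gaps lie within the scatter, so no order can be read among them.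

Compound 4, `CCN(CC)c1ccc2cc(C(=O)c3ccc(N4CCN(S(=O)(=O)c5ccc(Br)c(F)c5)CC4)cc3)oc2c1`, has not been measured. It differs from compound 3 by 4-bromo-3-fluorophenyl in place of 4-fluorophenyl on a sulfonyl sulfur.

The steps seen so far all exchange the group on that same aromatic ring: a 2.2-fold lower number from compound 1 to compound 2 (0.34 log units; beyond the scatter), a 1.5-fold lower number from compound 1 to compound 3 (0.17 log units; within the scatter) and a 1.5-fold higher number from compound 2 to compound 3 (0.17 log units; within the scatter). Only one of them reaches beyond the scatter, and even that one is modest. Exchanges at this ring have therefore moved this assay little. Compound 4 is expected to land close to compound 3, with the estimated step of a 1.4-fold lower number from compound 3 to compound 4 (0.14 log units; within the scatter) likely within the scatter or at most a small fall in the number.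

For compound 4 the estimated value in this assay is 12000 nM, with a range from 5000 nM to 30000 nM.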

Compound 4, half-maximal inhibitory concentration: 15100 nM
Compound 4: middle estimate off by 1.3-fold (0.10 log units), on the low side; the range from low to high includes it.
By their numbers in this assay, from the lowest: compounds 2, 4, 3 and 1 (each within the scatter of the next, the first and the last beyond it).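

Putting 4-bromo-3-fluorophenyl in place of 4-fluorophenyl on a sulfonyl sulfur adds a bromine and leaves a ring with two halogens, yet in this assay the change stays within the scatter (a 1.1-fold lower number from compound 3 to compound 4 (0.04 log units; within the scatter)). The new ring also cannot be told apart from the two other rings, as both remaining steps lie within the scatter (a 1.4-fold higher number from compound 2 to compound 4 (0.13 log units; within the scatter); a 1.6-fold lower number from compound 1 to compound 4 (0.21 log units; within the scatter)). The earlier compounds each carried a single group on this ring, so this is the first sign that a second substituent can be added here without a clear shift in this assay, although nothing shown explains this result.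

Among the four compounds, only the step between the nitro and trifluoromethyl compounds goes beyond the scatter, so the ring has so far shown very little range. As far as these compounds go, it remains open whether an amine or a carboxylic acid on this ring, or a longer alkyl chain in place of the ring on the sulfonyl sulfur, would move the number further than these halogen, trifluoromethyl and nitro variants do.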